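Amide variation on the carbonyl carbon: compound 3 to compound 4

A few compounds are considered here, and "the series" means these few. Any claim that something is new, unique, unknown or untested is made for them only; others in the source may bear on it.

Compound 3 `O=C(N1CCCCCC1)N1CC(c2nc(-c3cccc(Cl)c3)no2)C1` carries azepan-1-yl on the carbonyl carbon. In an assay on HEK293 cells for negative allosteric modulation of metabotropic glutamate receptor 5 (Homo sapiens), read by FLIPR (a lower number here means a stronger inhibitor, a higher number a weaker inhibitor), compound 3 gives only a limit, > 10000 nM. Compound 1 `O=C(C1CCC(F)(F)CC1)N1CC(c2nc(-c3cccc(Cl)c3)no2)C1` likewise returns a limit, > 10000 nM. Both sit on (the limit of > 10000 nM in this assay, at which 2 of the 3 values shown sit). Within the data shown here, compound 2 `COC1CCCN(C(=O)N2CC(c3nc(-c4cccc(Cl)c4)no3)C2)C1` supplies the one numbered value in this assay, 1830 nM. The step that the two limits leave unreadable from compound 1 to compound 3 cannot be sized; the step of an at least 5.4-fold higher number from compound 2 to compound 3 (0.73 log units; beyond the scatter) reads as at least modest. Compound 4 `O=C(C1CCC1)N1CC(c2nc(-c3cccc(Cl)c3)no2)C1` differs from compound 3 by cyclobutyl in place of azepan-1-yl on a carbonyl carbon. Among the measured compounds shown here, neither measured step tests a small carbocycle on the carbonyl carbon, and the only numbered value came with a different group. Compound 4 is therefore expected to remain near the limit, with an at least 1.2-fold lower number from compound 3 to compound 4 (0.09 log units; that floor lies within the scatter) an estimated step of uncertain size. The estimate for compound 4 is 8000 nM, within 2000 nM to 30000 nM.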

Compound 4, half-maximal inhibitory concentration: 1500 nM
The estimate for compound 4 lay 5.3-fold (0.73 log units) above the measured number; the measured number lies below the stated range.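

In this assay, cyclobutyl on the carbonyl carbon gives a numbered value where azepan-1-yl does not, with an at least 6.6-fold lower number from compound 3 to compound 4 (0.82 log units; beyond the scatter). A carbocycle alone does not suffice, as 4,4-difluorocyclohexyl shows, with an at least 6.6-fold lower number from compound 1 to compound 4 (0.82 log units; beyond the scatter). Nitrogen attached to the carbonyl carbon is not required for a numbered value either, and the two groups do not separate, with a 1.2-fold lower number from compound 2 to compound 4 (0.09 log units; within the scatter).

On these data alone, whether ring size governs this trend stays open, as cyclopropyl, cyclopentyl and unsubstituted cyclohexyl would test it. The full size of the two floors also stays open, as both rest on assay limits: the limit of > 10000 nM in this assay, at which 2 of the 4 values shown sit.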